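The source may hold more compounds than are shown below. What is called first, only, known or untested is meant among the compounds shown, and "the series" means these compounds.

In a functional assay on MCF7 cells (Homo sapiens) for antiproliferative activity (on this read-out higher numbers stand for weaker inhibition and lower numbers for stronger inhibition), compound 1 `CC(C)=CCc1cc(C(=O)Nc2cc3ccc(OCC4CCCN(C)C4)c(C)c3oc2=O)ccc1O` gives 2640 nM, the highest of the three numbers recorded. Compound 2 `CCCNCCCOc1ccc2cc(NC(=O)c3ccc(O)c(CC=C(C)C)c3)c(=O)oc2c1C` gives 980 nM and compound 3 `CC(C)=CCc1cc(C(=O)Nc2cc3ccc(OCCCN(C)C(C)C)c(C)c3oc2=O)ccc1O` gives 1050 nM in this assay; the steps are a 2.7-fold lower number from compound 1 to compound 2 (0.43 log units; beyond the scatter), a 2.5-fold lower number from compound 1 to compound 3 (0.40 log units; beyond the scatter) and a 1.1-fold higher number from compound 2 to compound 3 (0.03 log units; within the scatter). Compound 4 `CC(C)=CCc1cc(C(=O)Nc2cc3ccc(OCCCNc4ccccc4)c(C)c3oc2=O)ccc1O` differs from compound 1 by 2-anilinoethyl in place of 1-methylpiperidin-3-yl on a saturated chain carbon bound to an oxygen on an aromatic ring. Going by the values given here, both measured steps from compound 1 open the 1-methylpiperidin-3-yl ring into a chain amine and lowered the number modestly, so a modest lowering is expected here too, though the 2-anilinoethyl group has no measured counterpart. The estimate for compound 4 is 1500 nM, within 600 nM to 4000 nM, an expected step of a 1.8-fold lower number from compound 1 to compound 4 (0.25 log units; within the scatter).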

Compound 4, half-maximal inhibitory concentration: > 50000 nM
Compound 4: only a limit was reported; the forecaster's own chance of this, stated with the estimate: 5%; middle value at least 33-fold (1.52 log units) away from the limit.
By their numbers in this assay, from the lowest: compounds 2 and 3 (each within the scatter of the next); then compound 1. At a limit, above all of these: compound 4.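

The value of compound 4 is a limit, not a number: the limit of > 50000 nM in this assay, at which 1 of the 4 values shown sits. The chain on the aromatic oxygen therefore does not accept every amine, with steps of an at least 18-fold higher number from compound 1 to compound 4 (1.27 log units; beyond the scatter), an at least 47-fold higher number from compound 3 to compound 4 (1.67 log units; beyond the scatter) and an at least 51-fold higher number from compound 2 to compound 4 (1.70 log units; beyond the scatter). The last of these, phenyl in place of propyl on an amine nitrogen, shows that the group on this nitrogen can matter greatly, although the change from propylamino to isopropyl(methyl)amino gave only a 1.1-fold higher number from compound 2 to compound 3 (0.03 log units; within the scatter). Going by these compounds, it remains open whether the phenyl ring itself or its direct attachment to the nitrogen carries the change. A benzylamine or a cyclohexylamine at the end of the same chain would separate the two.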